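The compounds below may be only part of what the source reports. "The series", "measured", "known", "first", "only" and "open" are said of these compounds alone.

Compound 1 `COc1ccc(Cn2nnc(O)c2C(=O)Nc2cccc(C(F)(F)F)c2)cc1` gives 1.1
Compound 2 `COc1ccc(Cn2nnc(O)c2C(=O)Nc2cccc(-c3ccccc3)c2)cc1` gives 2.3

Going by the values given here, in a physicochemical assay for lipophilicity, read by spectrophotometry, using the shake flask method, in phosphate buffer, measured as octanol-water partition, with a stated time of 4 h, at pH 7.4 (a higher number here means a more lipophilic compound, a lower number a more polar compound), compound 2 stands highest of the two, at 2.3 with compound 1 as its only neighbour. Among the compounds with values here, the one measured step is a number 1.20 log units higher from compound 1 to compound 2 (beyond the scatter) with phenyl in place of trifluoromethyl on an aromatic carbon. Compound 3 `COc1ccc(Cn2nnc(O)c2C(=O)Nc2cccc(-c3ccc(O)cc3)c2)cc1` departs from compound 2 by hydroxy in place of hydrogen on an aromatic carbon. Within the data shown here, the measured step bears on this only loosely, as no measured pair adds a hydroxy, and the direction rests on the structural change alone. Starting from compound 2 at 2.3 a moderate fall is expected, clearly smaller than the measured step (a number 1.20 log units higher from compound 1 to compound 2 (beyond the scatter)). The estimated change is a number 0.60 log units lower from compound 2 to compound 3 (beyond the scatter) in this assay on this reasoning. Compound 3 is estimated at 1.7 with 1.2 to 2.2 as the expected range.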

Compound 3, distribution coefficient: 2.19
Estimate against measurement, compound 3: 0.49 log units below, within the range that was stated.
By their numbers in this assay, from the lowest: compound 1; then compounds 3 and 2 (each within the scatter of the next).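

In this assay the change from phenyl to 4-hydroxyphenyl gives a number 0.11 log units lower from compound 2 to compound 3 (within the scatter) and so does not separate the two compounds, even though the entering hydroxy brings a hydrogen-bond donor and a hydrogen-bond acceptor. The large rise over trifluoromethyl also persists with the hydroxy in place: 4-hydroxyphenyl gives a number 1.09 log units higher from compound 1 to compound 3 (beyond the scatter) and stands as a large step alongside a number 1.20 log units higher from compound 1 to compound 2 (beyond the scatter) on the same aromatic carbon. Nothing measured here offers an explanation for this result.

On these data alone, whether an amine or a carboxylic acid in place of the hydroxy would also leave the number unmoved remains open. So does whether a methoxy group there would behave as the hydroxy does, since a single substituent on this phenyl cannot establish a trend.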